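Formyl on the amino group of compound 2

A few compounds are considered here, and "the series" means these few. Any claim that something is new, unique, unknown or untested is made for them only; others in the source may bear on it.

Compound 1 `COc1cc(C2OC(c3ccc(N(C)C)cc3)=NN2C(=O)CO)cc(OC)c1OC` carries hydroxy and compound 2 `COc1cc(C2OC(c3ccc(N(C)C)cc3)=NN2C(=O)CN)cc(OC)c1OC` carries amino on a saturated chain carbon bound to a carbonyl carbon, on a shared core. In a functional assay on HCT-15 cells (Homo sapiens) (on this read-out higher numbers stand for an effect only at larger amounts of compound and lower numbers for an effect already at smaller amounts), compound 1 gives 0.026 uM and compound 2 gives 0.65 uM as its number, the higher of the two.

Compound 3 `COc1cc(C2OC(c3ccc(N(C)C)cc3)=NN2C(=O)CNC=O)cc(OC)c1OC` differs from compound 2 as follows: formyl in place of hydrogen on an amine nitrogen (formyl in place of hydrogen on an amine nitrogen, or amino to formylamino). Among the compounds with values here, no measured step covers this change directly. Within the data shown here, the one step available, a 25-fold higher number from compound 1 to compound 2 (1.40 log units; beyond the scatter) as a large move, bears on it only indirectly: it shows that the group on this chain carbon can shift the number a long way, yet formylamino is neither of the two groups compared there. A partial return toward compound 1 is therefore expected in this assay as a moderate move to a lower number. The estimated step is a 4.3-fold lower number from compound 2 to compound 3 (0.64 log units; beyond the scatter) with wide uncertainty. For compound 3 the estimate is 0.15 uM with an expected range from 0.03 uM to 0.8 uM in this read-out.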

Compound 3, concentration for half-maximal effect: 0.035 uM
The estimate for compound 3 lay 4.3-fold (0.63 log units) above the measured number; measured number inside the range.
By their numbers in this assay, from the lowest: compounds 1 and 3 (each within the scatter of the next); then compound 2.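

In this assay, formyl on the amine nitrogen gives a 19-fold lower number from compound 2 to compound 3 (1.27 log units; beyond the scatter), which shows that a nitrogen on this saturated chain carbon is compatible with a low number; among these three compounds, the high number belongs only to the free amino form. The comparison with the hydroxy compound gives a 1.3-fold higher number from compound 1 to compound 3 (0.13 log units; within the scatter), so hydroxy and formylamino cannot be told apart in this read-out, and compound 2 alone stands apart from the other two. Nothing available explains the size of either step.

The compounds shown leave open whether the return to a low number is specific to formyl or would also appear with a larger acyl group such as acetyl, or with a methanesulfonyl group on the same nitrogen. They also leave open how a methyl or dimethyl substitution on the amine nitrogen would read, and whether a carboxylic acid or a longer chain carrying the amino group would stay with compound 2 or move toward compound 1 and compound 3.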